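Moving a fluorine on the benzyl group of compound 2

The compounds below may be only part of what the source reports. "The series", "measured", "known", "first", "only" and "open" are said of these compounds alone.

Measured compounds:
- compound 1, `CCCn1c(=O)c2nc(-c3cnn(Cc4cccc(C)c4)c3)[nH]c2n(CCC)c1=O`, 36 nM
- compound 2, `CCCn1c(=O)c2nc(-c3cnn(Cc4ccc(F)cc4F)c3)[nH]c2n(CCC)c1=O`, 700 nM

Both were tested in an in vitro assay on HEK293 cells for displacement of a labelled ligand from adenosine receptor A2b (Homo sapiens); a lower number here means a stronger inhibitor, a higher number a weaker inhibitor. Compound 2 has the higher of the two numbers, so it is the weaker of the two inhibitors in this assay. Within the data shown here, the only measured step, a 19-fold higher number from compound 1 to compound 2 (1.29 log units; beyond the scatter), exchanges the whole ring on that chain carbon. Compound 3, `CCCn1c(=O)c2nc(-c3cnn(Cc4c(F)cccc4F)c3)[nH]c2n(CCC)c1=O`, keeps both fluorines but shifts one of them: 2,6-difluorophenyl in place of 2,4-difluorophenyl on a saturated chain carbon bound to an aromatic nitrogen. Among the measured compounds shown here, no measured pair shows the effect of moving a single fluorine within the same ring, so the step of a 19-fold higher number from compound 1 to compound 2 (1.29 log units; beyond the scatter) bears on it only loosely, by showing that this assay is sensitive to what sits on this benzyl group. With that in mind, compound 3 is expected to stay near compound 2, with a step of a 1.4-fold lower number from compound 2 to compound 3 (0.15 log units; within the scatter) that is not clearly beyond the scatter in either direction. The estimate for compound 3 in this assay is 500 nM, with a range from 100 nM to 2500 nM.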

Compound 3, inhibition constant: 390 nM
The estimate for compound 3 lay 1.3-fold (0.11 log units) above the measured number; the measured number falls inside the stated range.
By their numbers in this assay, from the lowest: compound 1; then compounds 3 and 2 (each within the scatter of the next).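

In this assay, among these compounds, the change from 2,4-difluorobenzyl to 2,6-difluorobenzyl gives a 1.8-fold lower number from compound 2 to compound 3 (0.25 log units; within the scatter), so the two fluorine patterns cannot be told apart in this assay, even though the earlier compounds showed that the group on this saturated chain carbon can matter a great deal. Among the compounds shown here, the comparison with the methyl-bearing ring gives an 11-fold higher number from compound 1 to compound 3 (1.03 log units; beyond the scatter), a gap of the same order as the one seen for compound 2, so both difluorophenyl rings tested here stand clearly on the weaker side of the 3-methylphenyl ring. No supporting measurement is available to explain either the close match between the two fluorine patterns or their gap to the 3-methylphenyl ring.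

Because the difluorophenyl rings differ from the 3-methylphenyl ring both in the kind of group and in how many groups they carry, these compounds cannot separate the effect of adding fluorine from that of losing the methyl. From the compounds shown here alone, it also remains open whether a ring with a single fluorine, or one with a chlorine or a methoxy group in place of the methyl of compound 1, would stay close to compound 1 or fall with the difluorophenyl compounds.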